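A few compounds are considered here, and "the series" means these few. Any claim that something is new, unique, unknown or untested is made for them only; others in the source may bear on it.

Measured compounds in a functional assay on cells (Melanoma cell, Homo sapiens) for cytotoxicity, read by sulforhodamine B assay, with a stated time of 48 h; a higher number here means a weaker inhibitor of growth, a lower number a stronger inhibitor of growth:
- compound 1 `COc1ccc(C2=NN(C3=NC(=O)/C(=C4\C(=O)Nc5ccc(Br)cc54)S3)C(c3ccc(Cl)cc3)C2)cc1` gives 160 nM
- compound 2 `COc1ccc(C2=NN(C3=NC(=O)/C(=C4\C(=O)Nc5ccc(Cl)cc54)S3)C(c3ccc(Cl)cc3)C2)cc1` gives 200 nM
- compound 3 `COc1ccc(-c2cc(-c3ccc(Cl)cc3)n(C3C(=O)Nc4ccc(Br)cc43)n2)cc1` gives 13200 nM

Compound 1 and compound 2 share a core and differ by one change, (chloro in place of bromo on an aromatic carbon); the step is a 1.3-fold higher number from compound 1 to compound 2 (0.10 log units; within the scatter). Compound 3 carries a different core; how the two cores differ is not broken down here, and compound 3 stands well apart from both compound 1 and compound 2 in this assay.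

Compound 4 `COc1ccc(-c2cc(-c3ccc(Cl)cc3)n(C3C(=O)Nc4ccc(Cl)cc43)n2)cc1` is not yet measured. It is related to compound 3 by chloro in place of bromo on an aromatic carbon, the same change as that from compound 1 to compound 2, at the same place. Since that step was within the scatter, compound 4 is expected to stay close to compound 3, with an expected step of a 1.2-fold higher number from compound 3 to compound 4 (0.08 log units; within the scatter) in this assay. The estimate for compound 4 is therefore 16000 nM, within 7000 nM to 35000 nM.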

Compound 4, concentration for 50% growth inhibition: 9400 nM
Estimate against measurement, compound 4: 1.7-fold (0.23 log units) above; the range from low to high includes it.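

In this assay chloro in place of bromo gives a 1.4-fold lower number from compound 3 to compound 4 (0.15 log units; within the scatter) on this second core. Set beside the same change on the core of compound 1, the two steps do not differ: the same change on two cores in this assay, a 1.3-fold higher number (0.10 log units; within the scatter) from compound 1 to compound 2 and a 1.4-fold lower number (0.15 log units; within the scatter) from compound 3 to compound 4, 1.8-fold (0.24 log units) apart, within the scatter of two such steps
So across these two cores the exchange of one halogen for the other can be carried over with no measurable shift, but this covers only bromo and chloro at this one place on two cores, and it says nothing about other cores or about the large gap between the two cores.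

Open, on these data alone, is whether a group other than these two halogens, such as fluoro, an amine or a carboxylic acid, would move the growth inhibition at this place. Also open, as far as these compounds go, is whether any such group would act alike on both cores.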